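The compounds below may be only part of what the source reports. "The series", "measured", "known", "first", "only" and "open" are said of these compounds alone.

Measured in a functional assay on B16-F10 cells (Mus musculus) for antiproliferative activity, read by MTT assay, with a stated time of 48 h; a lower number here means a stronger inhibitor, a higher number a weaker inhibitor:
- compound 1 `CCCC(C)Oc1ccc(C(=O)/C=C/c2c(/C=C/c3ccc(OC)cc3)cc(OC)cc2OC)cc1` gives 6.7 ug/mL
- compound 2 `COc1ccc(/C=C/c2cc(OC)cc(OC)c2/C=C/C(=O)c2ccc(C)cc2)cc1` gives 5.3 ug/mL
- compound 3 `COc1ccc(/C=C/c2cc(OC)cc(OC)c2/C=C/C(=O)c2ccc(C)cc2C)cc1` gives 4 ug/mL

Compound 3 cannot be separated from the other two, with a 1.3-fold lower number from compound 2 to compound 3 (0.12 log units; within the scatter) and a 1.7-fold lower number from compound 1 to compound 3 (0.22 log units; within the scatter). Compound 4 `COc1ccc(/C=C/c2cc(OC)cc(OC)c2/C=C/C(=O)c2ccc(C)c(C)c2)cc1` carries 3,4-dimethylphenyl in place of 2,4-dimethylphenyl on a carbonyl carbon. Within the data shown here, no measured pair differs only in where a methyl sits. The closest evidence is the addition of a methyl, a 1.3-fold lower number from compound 2 to compound 3 (0.12 log units; within the scatter), and the largest step in the series, a 1.7-fold lower number from compound 1 to compound 3 (0.22 log units; within the scatter), also stays small. The expected change is a 1.2-fold higher number from compound 3 to compound 4 (0.06 log units; within the scatter), with nothing expected beyond the scatter. For compound 4 the estimate is 4.6 ug/mL, with an expected range from 2.5 ug/mL to 8.5 ug/mL.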

Compound 4, half-maximal inhibitory concentration: 1.4 ug/mL
Compound 4: middle estimate off by 3.3-fold (0.52 log units), on the high side; measured number below the stated range.
By their numbers in this assay, from the lowest: compound 4; then compounds 3, 2 and 1 (each within the scatter of the next).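

In this assay the two methyls count by where they stand: 3,4-dimethylphenyl in place of 2,4-dimethylphenyl on a carbonyl carbon gives a 2.9-fold lower number from compound 3 to compound 4 (0.46 log units; beyond the scatter) and so moves beyond the scatter, with the same atoms, unlike all earlier steps. Methyl in place of hydrogen on an aromatic carbon gives a 3.8-fold lower number from compound 2 to compound 4 (0.58 log units; beyond the scatter) here against a 1.3-fold lower number from compound 2 to compound 3 (0.12 log units; within the scatter) for compound 3, and 3,4-dimethylphenyl in place of 4-(1-methylbutoxy)phenyl gives a 4.8-fold lower number from compound 1 to compound 4 (0.68 log units; beyond the scatter). No available measurement accounts for this difference.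

From the compounds shown here alone, whether 3,4-diethylphenyl or 3,4-dichlorophenyl on the same carbonyl carbon would keep the lower number remains open.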